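Sulfonamide nitrogen substituent variation on the shared core

The source may report more compounds than this note shows. Statements on the series, on what has been measured and on what is new or still open speak of the compounds shown alone.

Compound 1 `Cc1ccc(N(C)S(=O)(=O)C2CC3OC2C(c2ccc(NC(=O)CCCCCCC(=O)O)cc2)=C3c2ccc(O)cc2)cc1` reaches only a limit in a functional assay on DU-145 cells (Homo sapiens) for antiproliferative activity, read by MTT assay, with a stated time of 72 h (on this read-out lower numbers stand for stronger inhibition and higher numbers for weaker inhibition), > 100000 nM.
Compound 2 `COc1cccc(N(C)S(=O)(=O)C2CC3OC2C(c2ccc(NC(=O)CCCCCCC(=O)O)cc2)=C3c2ccc(O)cc2)c1` gives in this assay 62200 nM.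
Compound 3 `CN(c1cccc2ccccc12)S(=O)(=O)C1CC2OC1C(c1ccc(NC(=O)CCCCCCC(=O)O)cc1)=C2c1ccc(O)cc1` gives in this assay 70900 nM.

Compound 1 stands at a limit of the assay, not at a number (the limit of > 100000 nM in this assay, at which 1 of the 3 values shown sits), so its place below compounds 2 and 3 is only a floor. The measured steps on the sulfonamide nitrogen are an at least 1.6-fold lower number from compound 1 to compound 2 (0.20 log units; that floor lies within the scatter) and an at least 1.4-fold lower number from compound 1 to compound 3 (0.14 log units; that floor lies within the scatter); between them a 1.1-fold higher number from compound 2 to compound 3 (0.06 log units; within the scatter). Compound 4 `CCN(c1ccc(Cl)cc1)S(=O)(=O)C1CC2OC1C(c1ccc(NC(=O)CCCCCCC(=O)O)cc1)=C2c1ccc(O)cc1` differs from compound 1 at the same place: (4-chlorophenyl)(ethyl)amino in place of methyl(4-methylphenyl)amino on a sulfonyl sulfur. The two steps from compound 1 that bear on it gave floors within the scatter, so no step beyond the scatter is expected, giving an expected at least 1.1-fold lower number from compound 1 to compound 4 (0.07 log units; that floor lies within the scatter). Compound 4 is estimated at 85000 nM, between 40000 nM and 200000 nM.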

Compound 4, half-maximal inhibitory concentration: 42100 nM
Beside the measured number, compound 4's estimate is 2.0-fold (0.31 log units) above it; low and high end bracket the measured number.
By their numbers in this assay, from the lowest: compounds 4, 2 and 3 (each within the scatter of the next). At a limit, above all of these: compound 1.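

Within the data shown here, at the sulfonyl sulfur, (4-chlorophenyl)(ethyl)amino gives the only step that clears the scatter in this assay: an at least 2.3-fold lower number from compound 1 to compound 4 (0.37 log units; beyond the scatter). That step is only a floor, with compound 1 standing at a limit of the assay: the limit of > 100000 nM in this assay, at which 1 of the 4 values shown sits. Against the other two substituents the change stays within the scatter, with a 1.7-fold lower number from compound 3 to compound 4 (0.23 log units; within the scatter) and a 1.5-fold lower number from compound 2 to compound 4 (0.17 log units; within the scatter).

The ethyl and the chlorine enter together, so the compounds shown do not tell which of them carries the step. Also open, as far as these compounds go, is how a cyclohexyl or pyridyl group in place of the aromatic carbon ring would read.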